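Side chain at the amide-bearing carbon and tail flick activity

A few compounds are considered here, and "the series" means these few. Any claim that something is new, unique, unknown or untested is made for them only; others in the source may bear on it.

Compound 1 `N=C(N)NCCC[C@H](NC(=O)CN(c1ncnc2c1ncn2C1CCCCO1)C1CC1)C(=O)OCc1ccccc1`: in a functional assay on the whole organism (Tail, strain ICR) with Mus musculus as the target, in the tail flick test, with a stated time of 150 min, at a dose of 25 umol/kg by the oral route (a lower number here means a weaker effect, a higher number a stronger effect of the compound at the dose given), compound 1 gives 19.6%.
Compound 2 `CC(C)[C@H](NC(=O)CN(c1ncnc2c1ncn2C1CCCCO1)C1CC1)C(=O)OCc1ccccc1`: in this assay compound 2 gives 21.1%.
Compound 3 `O=C(CN(c1ncnc2c1ncn2C1CCCCO1)C1CC1)NCC(=O)OCc1ccccc1`: in this assay compound 3 gives 7.26%.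

Compound 3 stands lowest of the three in this assay; its nearest neighbour is compound 1, and compound 2 lies furthest from it, both beyond the scatter. Compound 4 `CC(C)C[C@H](NC(=O)CN(c1ncnc2c1ncn2C1CCCCO1)C1CC1)C(=O)OCc1ccccc1` differs from compound 3 in one place: isobutyl in place of hydrogen on a saturated chain carbon bound to an amide-type nitrogen and a carbonyl carbon. Going by the values given here, two measured steps bear on this change. Removing the side chain gave a number 13.8 percentage points lower from compound 2 to compound 3 (beyond the scatter), and the parallel removal gave a number 12.3 percentage points lower from compound 1 to compound 3 (beyond the scatter). The step to compound 4 runs the other way, putting a branched chain of four carbon atoms where compound 3 has a hydrogen, much as compound 2 has a chain of three carbon atoms. A gain of roughly the size of those steps is therefore expected in this assay, namely a number 13.7 percentage points higher from compound 3 to compound 4 (beyond the scatter). Compound 4 is estimated at 21%, within a range from 10% to 32%.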

Compound 4, a percentage reported as activity, at one dose (the size of the read-out at that dose, not a potency): 6.47%
For compound 4 the middle estimate is 14.5 percentage points above the measured one; measured number outside the range, below it.
By their numbers in this assay, from the lowest: compounds 4 and 3 (each within the scatter of the next); then compounds 1 and 2 (each within the scatter of the next).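

In this assay isobutyl gave no gain over hydrogen at this carbon, with a number 0.8 percentage points lower from compound 3 to compound 4 (within the scatter) as the step, so a carbon side chain here does not by itself raise the number. Isopropyl and isobutyl are not interchangeable at this position, as a number 14.6 percentage points lower from compound 2 to compound 4 (beyond the scatter) shows for a change of only one carbon count in the group. Going by these compounds alone, the step of a number 13.1 percentage points lower from compound 1 to compound 4 (beyond the scatter) likewise places isobutyl apart from the side chain of the arginine-type compound, so compound 4 goes against the pattern of higher numbers with a side chain that the earlier compounds suggested.

On these data alone, whether a longer unbranched chain, or an amine or carboxylic acid at the end of the side chain, would stand with isopropyl or with isobutyl remains open. Nothing at hand explains the gap between those two groups.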